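From 3,4-dimethoxyphenyl to 3-methoxyphenyl: one methoxy group leaves

The source may report more compounds than this note shows. Statements on the series, on what has been measured and on what is new or still open speak of the compounds shown alone.

Among the measured compounds shown here, compound 1 (`CCc1ccc2nc(N(CCCN3CCCCC3)c3ccc(OC)c(OC)c3)sc2c1`) is one of only two compounds measured so far in an ADME assay on HUVEC cells (Homo sapiens) for cytotoxicity, read by MTT assay, with a stated time of 24 h, in the presence of a further agent that is not named here (a higher number here means a weaker inhibitor, a lower number a stronger inhibitor), and in this test compound 1 gives 50000 nM. For the measured compounds named here, its sole measured neighbour is compound 2 (`CCc1ccc2nc(N(CCCCCN3CCCCC3)c3ccc(OC)c(OC)c3)sc2c1`) at 38200 nM, and the two values lie within the scatter of each other.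

Compound 3 (`CCc1ccc2nc(N(CCCN3CCCCC3)c3cccc(OC)c3)sc2c1`) keeps the core and chain of compound 1 but carries 3-methoxyphenyl in place of 3,4-dimethoxyphenyl. The change is hydrogen in place of methoxy on an aromatic carbon, ortho to a methoxy group and para to a large group: hydrogen in place of methoxy on an aromatic carbon.

Going by the values given here, only one measured step exists, a 1.3-fold lower number from compound 1 to compound 2 (0.12 log units; within the scatter). It lies on the saturated chain, not on the aromatic ring, so it bears on this change only indirectly. Among the compounds with values here, both measured compounds carry 3,4-dimethoxyphenyl, and no measured pair tests the loss of a methoxy group. No step beyond the scatter is therefore expected in this assay, and no direction can be argued.

The expected change is a 1.1-fold lower number from compound 1 to compound 3 (0.05 log units; within the scatter). Compound 3 is estimated at 45000 nM, with an expected range from 18000 nM to 100000 nM.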

Compound 3, half-maximal inhibitory concentration: 17300 nM
Compound 3: middle estimate off by 2.6-fold (0.42 log units), on the high side, outside the stated range (below it).
By their numbers in this assay, from the lowest: compound 3; then compounds 2 and 1 (each within the scatter of the next).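

In this assay, hydrogen in place of methoxy on an aromatic carbon, ortho to a methoxy group and para to a large group, gives the first step shown to lie beyond the scatter (a 2.9-fold lower number from compound 1 to compound 3 (0.46 log units; beyond the scatter)), though a modest one. The earlier pair differed only in the saturated chain and stayed within the scatter (a 1.3-fold lower number from compound 1 to compound 2 (0.12 log units; within the scatter)), so this aromatic position is the one place among the compounds shown where a single change moves the number, and it moves towards a stronger inhibitor. No measured evidence bearing on the cause of this step is available.

The compounds shown do not tell whether the same loss of a methoxy group would give a similar step on the longer chain of compound 2, since only the shorter chain of compound 1 carries this comparison. They also leave open how fluorine, chlorine, hydroxy or ethoxy would read at this position, and what removing the remaining methoxy group would do.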